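The compounds below may be only part of what the source reports. "The series", "measured", "known", "first", "only" and "open" are said of these compounds alone.

Measured so far in a functional assay on isolated protein for inhibition of Glucose-dependent insulinotropic receptor (Rattus norvegicus), read by HTRF and cAMP accumulation; a lower number here means that less compound is needed, a higher number that more compound is needed for the effect:

- compound 1 `Cc1nc(S(C)(=O)=O)ccc1Oc1ncnc(OC2CCN(C(=O)OC(C)F)CC2)c1F`: 315 nM
- compound 2 `Cc1nc(S(C)(=O)=O)ccc1Oc1ncnc(OC2CCN(C(=O)OC3(C(F)(F)F)COC3)CC2)c1F`: 342 nM
- compound 3 `Cc1nc(S(C)(=O)=O)ccc1Oc1ncnc(OC2CCN(C(=O)SC3CC3)CC2)c1F`: 126 nM

All three share the same core and differ only in the group on the carbonyl carbon attached to the ring nitrogen. Compound 1 stands second highest of the three numbers in this assay; compound 2 sits nearest to it, a 1.1-fold higher number from compound 1 to compound 2 (0.04 log units; within the scatter), and compound 3 is furthest, a 2.5-fold lower number from compound 1 to compound 3 (0.40 log units; beyond the scatter). The step from compound 2 to compound 3 is of the same kind, a 2.7-fold lower number from compound 2 to compound 3 (0.43 log units; beyond the scatter).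

Compound 4 `Cc1nc(S(C)(=O)=O)ccc1Oc1ncnc(OC2CCN(C(=O)C(C)(C)F)CC2)c1F` is the next point in this position. Relative to compound 1 the change is a group of 4 heavy atoms (3 carbon, 1 fluorine; no ring) in place of a group of 4 heavy atoms (2 carbon, 1 oxygen, 1 fluorine; no ring), on a carbonyl carbon. The measured steps that bear on it are those at the same carbonyl carbon: swapping one oxygen-linked group for another, from compound 1 to compound 2, left the number within the scatter, while moving to a sulfur-linked cyclopropyl, from compound 1 to compound 3, gave a modest lower number. Going by the values given here, no measured pair covers a carbon-linked group at this carbon, so the direction is not fixed by the data; a step within the scatter, or at most a modest one in either direction, is the expectation in this assay.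

For compound 4 the estimate in this assay is 260 nM, with a range from 110 nM to 620 nM. This corresponds to an expected step of a 1.2-fold lower number from compound 1 to compound 4 (0.08 log units; within the scatter).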

Compound 4, half-maximal effective concentration: 296 nM
Estimate against measurement, compound 4: 1.1-fold (0.06 log units) below, within the range that was stated.
By their numbers in this assay, from the lowest: compound 3; then compounds 4, 1 and 2 (each within the scatter of the next).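

In this assay, going by these compounds alone, the 1-fluoro-1-methylethyl group is the first carbon-linked group at this carbonyl carbon, and it gives a 1.1-fold lower number from compound 1 to compound 4 (0.03 log units; within the scatter) and also a 1.2-fold lower number from compound 2 to compound 4 (0.06 log units; within the scatter) in the comparison with the (3-(trifluoromethyl)oxetan-3-yl)oxy group. An oxygen link at this carbon is therefore not required to keep the number in the range of compound 1 and compound 2, and the change from 1-fluoroethyl bound through oxygen to the carbon-linked group leaves the read-out indistinguishable from the scatter. Against the sulfur-linked cyclopropyl the same group shows a 2.3-fold higher number from compound 3 to compound 4 (0.37 log units; beyond the scatter) in this series, so compound 3 remains the only one of the four set apart from the others, and nothing on hand offers a reason for these numbers.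

The compounds shown leave open whether the lower number of compound 3 follows from the sulfur link or from the cyclopropyl ring, since no cyclopropyl bound through oxygen or directly to the carbonyl carbon stands among them. From the compounds shown here alone, how an amine on this carbonyl carbon, such as cyclopropylamino, would read in this assay also remains open.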